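This account rests on a few compounds, and the source may have more. Where it says the series, first, only, none or still open, it means among the compounds named here.

Compound 1, `CCCc1nc(-c2ccccc2)c(CNCCN2CCN(C(c3ccccc3)c3ccccc3)CC2)o1`: 7470 nM
Compound 2, `CCCc1nc(-c2ccccc2)c(CNCCN2CCN(c3ccccc3Cl)CC2)o1`: 4370 nM
Compound 3, `CCCc1nc(-c2ccccc2)c(CNCCCN2CCN(c3cccc(C)c3)CC2)o1`: 1190 nM

In an assay on HEK293 cells for inhibition of Voltage-dependent T-type calcium channel subunit alpha-1G (Homo sapiens), read by patch clamp (on this read-out higher numbers stand for weaker inhibition and lower numbers for stronger inhibition), compound 3 stands at the lowest number of the three; compound 2 sits at a gap beyond the scatter, and compound 1 lies further off still. Compound 4, `CCCc1nc(-c2ccccc2)c(CNCCCN2CCN(c3cccc(F)c3)CC2)o1`, differs from compound 3 in a single place: fluoro in place of methyl on an aromatic carbon. Among the measured compounds shown here, no measured pair in this set carries that same change, so its effect can only be estimated. The expected step of a 1.3-fold higher number from compound 3 to compound 4 (0.13 log units; within the scatter) is judged to be small, most likely within the scatter or a little toward a higher number. Compound 4 is therefore expected to give about 1600 nM in this assay, with a range from 600 nM to 4500 nM.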

Compound 4, half-maximal inhibitory concentration: 3030 nM
Beside the measured number, compound 4's estimate is 1.9-fold (0.28 log units) below it; low and high end bracket the measured number.
By their numbers in this assay, from the lowest: compound 3; then compounds 4, 2 and 1 (each within the scatter of the next, the first and the last beyond it).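

Fluoro in place of methyl on an aromatic carbon gives a 2.5-fold higher number from compound 3 to compound 4 (0.41 log units; beyond the scatter) in this assay, the first step in this set that changes only one place. It shows that this position on the 3-methylphenyl group responds to the change, with the methyl-bearing compound 3 holding the lower number of the pair. No evidence at hand accounts for the step.

The compounds shown leave open how a chloro, methoxy or trifluoromethyl group on the same carbon would read. They also leave open whether this change would shift the number similarly with the shorter chain of compound 2.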